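The source may hold more compounds than are shown below. What is called first, only, known or untested is meant among the compounds shown, and "the series" means these compounds.

Three related compounds have been measured in a physicochemical assay for lipophilicity; on this read-out higher numbers stand for higher lipophilicity and lower numbers for lower lipophilicity. Compound 1, `CCCOC(=O)/C=C(C)/C=C/CC(C)CCCC(C)C`, gives 7.28. Compound 2, `COC(C)(C)CCCC(C)C/C=C/C(C)=C/C(=O)OCCC(C)C`, gives 7.03. Compound 3, `CCOC(C)(C)CCCC(C)C/C=C/C(C)=C/C(=O)OC(C)C`, gives 6.49. Among these three numbers compound 2 stands second highest: the gap to compound 1 lies within the usual scatter of this kind of measurement, so the two cannot be told apart, while compound 3 sits clearly lower, by a gap beyond the scatter.

The next compound, compound 4, `COC(C)(C)CCCC(C)C/C=C/C(C)=C/C(=O)CC(C)C`, has not yet been measured. It differs from compound 2 in one place only: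

isobutyl in place of isopentyloxy on a carbonyl carbon

Among the measured compounds shown here, none of the measured pairs shares this change, so there is no measured step to lean on. The change removes the single hydrogen-bond acceptor of the isopentyloxy group together with two heavy atoms, and what enters is a shorter all-carbon isobutyl group. Taken together, the expectation for compound 4 is a modest downward step in this assay, close to the edge of the scatter, namely a number 0.38 log units lower from compound 2 to compound 4 (beyond the scatter). On that basis compound 4 is estimated at 6.65, within a range from 6.2 to 7.1.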

Compound 4, partition coefficient: 6.02
Compound 4: the middle estimate sits 0.63 log units above what was measured, outside the stated range (below it).
By their numbers in this assay, from the lowest: compound 4; then compound 3; then compounds 2 and 1 (each within the scatter of the next).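

In this assay, putting isobutyl in place of isopentyloxy on a carbonyl carbon gives a number 1.01 log units lower from compound 2 to compound 4 (beyond the scatter), a large step and the first here that can be read for a change in one place only. It shows that the group on this carbonyl carbon matters for this read-out: with the rest of the structure shared, the two compounds end up clearly apart. The swap changes several things at once, since 6 heavy atoms with 1 hydrogen-bond acceptor leave and 4 heavy atoms with 0 hydrogen-bond acceptors enter, and no measurement shown here accounts for the size of the step.

From the compounds shown here alone, it remains open whether the step goes with the loss of the oxygen or with the shorter chain, and an isobutoxy group on the same carbonyl carbon, which holds both the oxygen and the isobutyl chain, would pull these two apart. Also open, going by these compounds, are how an isobutylamino group at this place would read, and whether a step of this size would recur on a different version of the shared core.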